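Butyl in place of tert-butyl on compound 1

The source may report more compounds than this note shows. Statements on the series, on what has been measured and on what is new or still open speak of the compounds shown alone.

In an ADME assay on MT4 cells (Homo sapiens) for cytotoxicity (a higher number here means that more compound is tolerated, a lower number that less compound is tolerated), compound 1 `CC(=O)OC[C@H]1O[C@@H](n2cc(-c3cc(-c4ccc(C(C)(C)C)cc4)no3)c(=O)[nH]c2=O)C[C@@H]1OC(C)=O` gives 3000 nM and compound 2 `CC(C)(C)c1ccc(-c2cc(-c3cn([C@H]4C[C@H](O)[C@@H](CO)O4)c(=O)[nH]c3=O)on2)cc1` gives 3000 nM, so the two stand level. Compound 3 `CCCCc1ccc(-c2cc(-c3cn([C@H]4C[C@H](OC(C)=O)[C@@H](COC(C)=O)O4)c(=O)[nH]c3=O)on2)cc1` differs from compound 1 by butyl in place of tert-butyl on an aromatic carbon. For the measured compounds named here, no measured pair shows the effect of this swap, so no shift beyond the scatter is expected in this assay, in either direction. The estimated change is no change at the digits printed from compound 1 to compound 3 (within the scatter). For compound 3 the expected value is 3000 nM, with an estimated range of 1200 nM to 8000 nM.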

Compound 3, half-maximal cytotoxic concentration: 3000 nM
For compound 3 middle estimate and measured number coincide at the digits printed; low and high end bracket the measured number.
By their numbers in this assay, from the lowest: compounds 1, 2 and 3 (each within the scatter of the next).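

In this assay, replacing tert-butyl with butyl on the aromatic carbon, 4-(tert-butyl)phenyl to 4-butylphenyl, gives no change at the digits printed from compound 1 to compound 3 (within the scatter). For the compounds shown here, this is the first step read at this position: with the acetate esters in place, the straight butyl chain and the branched tert-butyl group read alike in this cytotoxicity measure. No supporting data bear on why the two groups read alike.

Still open, from the compounds shown here alone, is whether an amine, a carboxylic acid or a longer chain at this position would read the same. Also open, going by these compounds, is whether butyl reads the same on the free-hydroxyl form seen in compound 2.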